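Replacing the tetrahydroquinolinyl group of compound 3

The source may hold more compounds than are shown below. What is called first, only, known or untested is meant among the compounds shown, and "the series" means these compounds.

Measured in a functional assay on Shh Light II cells (Mus musculus) for inhibition, read by a luciferase reporter; a lower number here means a stronger inhibitor, a higher number a weaker inhibitor:
- compound 1 `O=C(Nc1ccccc1Cl)N1CCC(c2nc(-c3ccc4ccccc4n3)no2)CC1` gives 510 nM
- compound 2 `O=C(CC1CCCCCC1)N1CCC(c2nc(-c3ccc4ccccc4n3)no2)CC1` gives 840 nM
- compound 3 `O=C(N1CCC(c2nc(-c3ccc4ccccc4n3)no2)CC1)N1CCCc2ccccc21` gives 2300 nM

Compound 3 has the highest number of the three and is the weakest inhibitor in this assay, at 2300 nM. Compound 4 `O=C(NC1CCS(=O)(=O)CC1)N1CCC(c2nc(-c3ccc4ccccc4n3)no2)CC1` keeps the shared core but carries (1,1-dioxothian-4-yl)amino in place of 1,2,3,4-tetrahydroquinolin-1-yl on a carbonyl carbon.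

Going by the values given here, three measured steps concern this same place. The first is a 4.5-fold higher number from compound 1 to compound 3 (0.65 log units; beyond the scatter), the second is a 2.7-fold higher number from compound 2 to compound 3 (0.44 log units; beyond the scatter), and the third, within the scatter, is a 1.6-fold higher number from compound 1 to compound 2 (0.22 log units; within the scatter). Changes here have therefore been modest at most. Compound 1, at 510 nM, also has an amino group at this place, but no measured group contains the entering sulfur, so the data give no firm direction. A step of similar or smaller size is expected. The estimated change is a 1.3-fold higher number from compound 3 to compound 4 (0.12 log units; within the scatter). The expected value for compound 4 is 3000 nM, with an estimated range of 700 nM to 12000 nM.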

Compound 4, half-maximal inhibitory concentration: 360 nM
Compound 4: the middle estimate sits 8.3-fold (0.92 log units) above what was measured; the measured number lies below the stated range.
By their numbers in this assay, from the lowest: compounds 4, 1 and 2 (each within the scatter of the next, the first and the last beyond it); then compound 3.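

A saturated ring bearing two oxygens on its sulfur is accepted at this place on the carbonyl carbon, with a 6.4-fold lower number from compound 3 to compound 4 (0.81 log units; beyond the scatter) and a 2.3-fold lower number from compound 2 to compound 4 (0.37 log units; beyond the scatter) as the two steps beyond the scatter. On the amide-type nitrogen, the change to the 1,1-dioxothian-4-yl group gives a 1.4-fold lower number from compound 1 to compound 4 (0.15 log units; within the scatter), so this group and 2-chlorophenyl cannot be told apart here, and an aromatic ring on that nitrogen is not required. Nothing available explains why the new group outperforms the tetrahydroquinolinyl and cycloheptylmethyl groups.

The compounds shown leave open whether the two oxygens matter or the ring alone suffices, a question that a plain thian-4-yl or oxan-4-yl group on the same nitrogen would address. They also leave open how an amine or a carboxylic acid on this ring would fare.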